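This account rests on a few compounds, and the source may have more. Where it says the series, first, only, none or still open, it means among the compounds named here.

Measured so far:
Compound 1, `Cc1ccccc1NC(=O)NC1CC(C)(C)Oc2ccc(Cl)cc21`, in a functional assay (aorta) with Rattus norvegicus as the target (on this read-out lower numbers stand for an effect already at smaller amounts and higher numbers for an effect only at larger amounts of compound), gives only a limit, > 10000 nM.
Compound 2, `CC1(C)CC(NC(=O)Nc2ccccc2Cl)c2cc(Cl)ccc2O1`, in this assay gives only a limit, > 300000 nM.

Compound 2 therefore stands at a limit of the assay, as shown by the limit of > 300000 nM in this assay, at which 1 of the 2 values shown sits, and compound 1 likewise sits at a limit, (the limit of > 10000 nM in this assay, at which 1 of the 2 values shown sits). Going by the values given here, the one measured step, a step that the two limits leave unreadable from compound 1 to compound 2, cannot be read because both ends are limits. Compound 3, `CC1(C)CC(NC(=O)Nc2ccc(Cl)cc2)c2cc(Cl)ccc2O1`, differs from compound 2 by 4-chlorophenyl in place of 2-chlorophenyl on an amide-type nitrogen. Among the compounds with values here, no measured step bears on this change, so its size and direction remain open. Given that compound 2 reaches only a limit in this assay, compound 3 is expected to give a weak or unmeasurable effect as well, estimated at 100000 nM with a range from 10000 nM to 1000000 nM. The expected step is then an at least 3.0-fold lower number from compound 2 to compound 3 (0.47 log units; beyond the scatter), most likely again reported only as a limit.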

Compound 3, half-maximal effective concentration: > 300000 nM
Compound 3: a limit, no number (the forecaster's own chance of this, stated with the estimate: 80%); middle value at least 3.0-fold (0.47 log units) away from the limit.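

Going by these compounds alone, compound 1, compound 2 and compound 3 all give only limits in this assay, not numbers, and no step among them can be read. Going by these compounds, it stays open whether 4-chlorophenyl and 2-chlorophenyl differ at all, and at what concentration, if any, these compounds show an effect.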